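Removing one chloro from the dichlorophenyl sulfone

The compounds below may be only part of what the source reports. "The series", "measured", "known", "first", "only" and "open" are said of these compounds alone.

Of the compounds shown here, two from a set of aryl sulfones have been measured in an assay on isolated protein for displacement of a labelled ligand from metabotropic glutamate receptor 5 (Homo sapiens), with a stated time of 60 min, tested at 1 uM; a lower number here means less inhibition, a higher number more inhibition at the concentration tested (going by the name of the read-out). Compound 1 `CC1CCN(c2c(S(=O)(=O)c3ccc(Cl)c(Cl)c3)cnc3cc(F)ccc23)CC1` carries a 3,4-dichlorophenyl sulfone on the shared core; in this assay compound 1 gives 94%. Compound 2 `COc1ccc(S(=O)(=O)c2cnc3ccc(F)cc3c2N2CCC(C)CC2)cc1` differs at several places at once, and in this assay compound 2 gives 85%. The two numbers lie within the usual scatter of each other, so nothing can be said about which compound inhibits more; compound 1 is simply the starting point for the step considered here.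

Compound 3 `CC1CCN(c2c(S(=O)(=O)c3ccc(Cl)cc3)cnc3cc(F)ccc23)CC1` is derived from compound 1 by a single change: hydrogen in place of chloro on an aromatic carbon. Among the measured compounds shown here, no pair of measured compounds differing in one place is available to calibrate this change, so the expectation rests on the structures alone. Since compound 1 already sits near the top of the read-out with 94%, there is little room upward, and a modest loss is expected. The estimated step is a number 10 percentage points lower from compound 1 to compound 3 (within the scatter), a drop that may or may not exceed the scatter. Compound 3 is therefore expected to give about 84%, with a range from 65% to 96%.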

Compound 3, a percentage reported as inhibition, at one concentration (the size of the read-out at that concentration, not a potency): 90%
Beside the measured number, compound 3's estimate is 6 percentage points below it; low and high end bracket the measured number.
By their numbers in this assay, from the lowest: compounds 2, 3 and 1 (each within the scatter of the next).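

Among the compounds shown here, this is the first step in the set that changes a single place: a number 4 percentage points lower from compound 1 to compound 3 (within the scatter) in this assay, with 3,4-dichlorophenyl becoming 4-chlorophenyl through hydrogen in place of chloro on an aromatic carbon. It shows that, at the concentration tested, this read-out does not separate the two compounds, so the chloro that leaves is not required for compound 3 to give a high reading, although a percentage at one concentration is not a potency and a difference in potency could remain unseen. No measurement shown here offers an explanation for this result.

Whether the remaining chloro matters stays open, as a phenyl sulfone with no chloro at all, or one with a fluoro, methyl or trifluoromethyl group in its place, does not appear among the compounds shown. On these data alone, it is also open how a group such as methoxy, nitrile or a carboxylic acid would read at the position the chloro left, and whether full concentration-response measurements would tell compound 1 and compound 3 apart.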